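The source may hold more compounds than are shown below. What is called first, only, known or untested is meant among the compounds shown, and "the series" means these compounds.

Measured so far:
compound 1 `CCn1cc(-c2cc(C(O)(C(F)(F)F)C(F)(F)F)cnc2N2CCN(S(=O)(=O)c3ccc(N)nc3)CC2)cn1` — 194 mL.min-1.g-1
compound 2 `Nc1ccc(S(=O)(=O)N2CCN(c3ncc(C(O)(C(F)(F)F)C(F)(F)F)cc3-c3cccc(F)c3)CC2)cn1` — 52 mL.min-1.g-1
compound 3 `Nc1ccc(S(=O)(=O)N2CCN(c3ncc(C(O)(C(F)(F)F)C(F)(F)F)cc3-c3cccnc3)CC2)cn1` — 20 mL.min-1.g-1

In an ADME assay (liver) for metabolic stability, with Liver microsome (Rattus norvegicus) as the target, using microsomes and NADPH, with a stated time of 30 min, tested at 1 uM (a lower number here means slower removal, a higher number faster removal of the compound), compound 1 gives the highest of the three numbers, so it is removed fastest among them. Compound 4 `Cc1nc2cc(-c3cc(C(O)(C(F)(F)F)C(F)(F)F)cnc3N3CCN(S(=O)(=O)c4ccc(N)nc4)CC3)ccc2o1` differs from it in one place: 2-methyl-1,3-benzoxazol-5-yl in place of 1-ethyl-1H-pyrazol-4-yl on an aromatic carbon. The two measured steps that bear on this swap both replace the same group on the same aromatic carbon: a 3.7-fold lower number from compound 1 to compound 2 (0.57 log units; beyond the scatter) and a 9.7-fold lower number from compound 1 to compound 3 (0.99 log units; beyond the scatter). Both lowered the number well beyond the scatter, with the pyridin-3-yl change the larger of the two. Within the data shown here, only two such swaps are known, and neither enters a bicyclic group, so the size of the step for compound 4 is uncertain, but a decrease is expected. For compound 4 the estimated step is a 2.8-fold lower number from compound 1 to compound 4 (0.44 log units; beyond the scatter), giving an expected value of 70 mL.min-1.g-1 with a range from 25 mL.min-1.g-1 to 200 mL.min-1.g-1.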

Compound 4, intrinsic clearance in microsomes: 99 mL.min-1.g-1
Estimate against measurement, compound 4: 1.4-fold (0.15 log units) below; the range from low to high includes it.
By their numbers in this assay, from the lowest: compound 3; then compounds 2, 4 and 1 (each within the scatter of the next, the first and the last beyond it).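

In this assay, the two-ring 2-methyl-1,3-benzoxazol-5-yl group stays within the scatter of both the 1-ethyl-1H-pyrazol-4-yl group (a 2.0-fold lower number from compound 1 to compound 4 (0.29 log units; within the scatter)) and the 3-fluorophenyl group (a 1.9-fold higher number from compound 2 to compound 4 (0.28 log units; within the scatter)). Only the pyridin-3-yl group stands apart (a 5.0-fold higher number from compound 3 to compound 4 (0.69 log units; beyond the scatter)), so at this aromatic carbon, a second ring does not by itself move the number beyond the scatter of compound 1. Nothing available explains these numbers. Still open, as far as these compounds go, is how a morpholine or a carboxylic acid on this aromatic carbon would compare with compound 3.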